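From 1-benzofuran-2-yl to ethynyl: one open step

The compounds below may be only part of what the source reports. "The series", "measured", "known", "first", "only" and "open" are said of these compounds alone.

Measured so far in a functional assay on HL-60 cells (Homo sapiens) for antiproliferative activity, read by XTT assay, with a stated time of 72 h; on this read-out higher numbers stand for weaker inhibition and lower numbers for stronger inhibition:
- compound 1 `COc1ncnc2c1c(-c1ccccc1)cn2[C@@H]1O[C@H](CO)[C@@H](O)[C@H]1O`: > 20000 nM
- compound 2 `COc1ncnc2c1c(-c1cc3ccccc3o1)cn2[C@@H]1O[C@H](CO)[C@@H](O)[C@H]1O`: 4470 nM

The entry for compound 1, > 20000 nM, is a limit of the assay and not a number. Going by the values given here, that leaves compound 2, at 4470 nM, with the only true number so far. Compound 3 `C#Cc1cn([C@@H]2O[C@H](CO)[C@@H](O)[C@H]2O)c2ncnc(OC)c12` carries ethynyl in place of 1-benzofuran-2-yl on an aromatic carbon. Among the compounds with values here, the one measured step, an at least 4.4-fold lower number from compound 1 to compound 2 (0.65 log units; beyond the scatter), is an at least modest change on that same carbon, but it involved no ethynyl and so offers only a loose guide. A step no larger than that one is therefore expected in this assay, leaning towards lower numbers with much uncertainty. The expected change is a 2.2-fold lower number from compound 2 to compound 3 (0.35 log units; beyond the scatter). The estimated value for compound 3 is 2000 nM, within a range of 150 nM to 20000 nM.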

Compound 3, half-maximal inhibitory concentration: 190 nM
Estimate against measurement, compound 3: 11-fold (1.02 log units) above, within the range that was stated.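

In this assay, ethynyl on this carbon gives a change that the two ring-bearing groups did not hint at: a 24-fold lower number from compound 2 to compound 3 (1.37 log units; beyond the scatter), and an at least 100-fold lower number from compound 1 to compound 3 (2.02 log units; beyond the scatter). Among the compounds shown, the group with only two carbons and no ring therefore goes with the strongest inhibition, and both steps are large. The second step starts from compound 1, whose entry is a limit of the assay and not a number: the limit of > 20000 nM in this assay, at which 1 of the 3 values shown sits.

On these data alone, it stays open whether the triple bond itself matters or only the loss of the rings. An ethyl, vinyl or propynyl group on this carbon would help to separate the two.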